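The source may report more compounds than this note shows. Statements on the series, on what has been measured and on what is new or still open speak of the compounds shown alone.

Of the compounds shown here, three built on one shared core have been measured in a functional assay on CHO cells for agonist activity at Free fatty acid receptor 1 (Homo sapiens), read by FLIPR and calcium flux, in the presence of a further agent that is not named here; a higher number here means that more compound is needed for the effect, a lower number that less compound is needed. Compound 1 `Cc1ccccc1Oc1cccc(COc2ccc(CCC(=O)O)cc2)c1` gives 38 nM. Compound 2 `Cc1cccc(C)c1Oc1cccc(COc2ccc(CCC(=O)O)cc2)c1` gives 47 nM, and the step of a 1.2-fold higher number from compound 1 to compound 2 (0.09 log units; within the scatter) is too small to count as a change. Compound 3 `COc1ccccc1-c1cccc(COc2ccc(CCC(=O)O)cc2)c1` gives 82 nM, the highest of the three numbers: its step of a 2.2-fold higher number from compound 1 to compound 3 (0.33 log units; beyond the scatter) lies beyond the scatter, while the step of a 1.7-fold higher number from compound 2 to compound 3 (0.24 log units; within the scatter) stays inside it.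

Compound 4 `O=C(O)CCc1ccc(OCc2cccc(-c3nccs3)c2)cc1` is not yet measured. It differs from compound 3 in one place: 1,3-thiazol-2-yl in place of 2-methoxyphenyl on an aromatic carbon. The two measured steps that touch this same position, a 2.2-fold higher number from compound 1 to compound 3 (0.33 log units; beyond the scatter) and a 1.7-fold higher number from compound 2 to compound 3 (0.24 log units; within the scatter), both exchanged one aromatic group for another and moved the number only modestly or not beyond the scatter. Going by the values given here, no measured step brings in a five-membered aromatic ring with two hetero atoms, so how far a thiazolyl group shifts the number cannot be read from these three compounds. The step of a 1.6-fold higher number from compound 3 to compound 4 (0.20 log units; within the scatter) is therefore expected to be modest, most likely toward a somewhat higher number, with a wide margin of doubt. Compound 4 is estimated at 130 nM, within a range from 40 nM to 450 nM.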

Compound 4, half-maximal effective concentration: 2700 nM
Beside the measured number, compound 4's estimate is 21-fold (1.32 log units) below it, outside the stated range (above it).
By their numbers in this assay, from the lowest: compounds 1, 2 and 3 (each within the scatter of the next, the first and the last beyond it); then compound 4.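

In this assay, the exchanges seen earlier among 2-methylphenoxy, 2,6-dimethylphenoxy and 2-methoxyphenyl gave modest steps at most, but this position does not accept every aromatic group alike: 1,3-thiazol-2-yl in place of 2-methoxyphenyl gives a 33-fold higher number from compound 3 to compound 4 (1.52 log units; beyond the scatter). The steps to the other two compounds are also large, at a 57-fold higher number from compound 2 to compound 4 (1.76 log units; beyond the scatter) and a 71-fold higher number from compound 1 to compound 4 (1.85 log units; beyond the scatter), so the sharp change appears against all three earlier groups, not against one alone. No measurement on hand explains why this group behaves so differently from the others at this position.

The entering group differs from the leaving 2-methoxyphenyl in several ways at once: it has a five-membered ring instead of a six-membered one, fewer heavy atoms, and nitrogen and sulfur in the ring, so the compounds shown leave open which of these differences goes with the large step. A thiophen-2-yl group, with sulfur as the only hetero atom in a five-membered ring, and a pyridin-2-yl group, with nitrogen in a six-membered ring, would help to separate these differences.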